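The compounds below may be only part of what the source reports. "The series", "measured", "known", "first", "only" and "open" are said of these compounds alone.

Measured so far in a functional assay on HT-1080 cells (Homo sapiens), read by transwell migration, with a stated time of 24 h, tested at 10 uM; on this read-out lower numbers stand for a stronger effect and higher numbers for a weaker effect at the one concentration tested:
compound 1 `CC(=O)OCc1ccc2oc(=O)c(C(=O)Oc3cccc(Cl)c3)cc2c1` gives 6.17%
compound 2 `CC(=O)OCc1ccc2oc(=O)c(C(=O)Oc3cccc(Br)c3)cc2c1` gives 11.8%
compound 3 `CC(=O)OCc1ccc2oc(=O)c(C(=O)Sc3cccc(Cl)c3)cc2c1` gives 61.9%

Compound 4 `CC(=O)OCc1ccc2oc(=O)c(C(=O)Sc3cccc(Br)c3)cc2c1` has not yet been measured. Between compound 1 and compound 2 the change is bromo in place of chloro on an aromatic carbon, and it made a step of a number 5.6 percentage points higher from compound 1 to compound 2 (within the scatter). Compound 4 arises from compound 3 by the same change, (bromo in place of chloro on an aromatic carbon), on the same place. The two cores differ in that compound 3 carries (3-chlorophenyl)sulfanyl in place of 3-chlorophenoxy on a carbonyl carbon, a change that made a step of a number 55.7 percentage points higher from compound 1 to compound 3 (beyond the scatter). Because the earlier step of a number 5.6 percentage points higher from compound 1 to compound 2 (within the scatter) stayed within the scatter, the step from compound 3 to compound 4 in this assay is expected to be small as well, about a number 4.1 percentage points higher from compound 3 to compound 4 (within the scatter). Compound 4 is therefore estimated at 66%, with a likely range from 50% to 82%.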

Compound 4, a percentage reported as activity, at one concentration (the size of the read-out at that concentration, not a potency): 67.8%
For compound 4 the middle estimate is 1.8 percentage points below the measured one; the range from low to high includes it.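

In this assay, bromo in place of chloro on an aromatic carbon gave a number 5.9 percentage points higher from compound 3 to compound 4 (within the scatter), and this small step carried over from one core to the other: the same change on two cores in this assay, a number 5.6 percentage points higher (within the scatter) from compound 1 to compound 2 and a number 5.9 percentage points higher (within the scatter) from compound 3 to compound 4, 0.3 percentage points apart, within the scatter of two such steps The large steps lie elsewhere, in the change from the phenoxy to the sulfanyl group, with a number 56 percentage points higher from compound 2 to compound 4 (beyond the scatter) and a number 61.6 percentage points higher from compound 1 to compound 4 (beyond the scatter). Among these compounds, this shows only that this one halogen exchange stays within the scatter on these two cores; it does not show that other changes would carry across in the same way, or that this one would on a third core.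

The compounds shown leave open how a fluoro group, an amine or a carboxylic acid in place of the chloro or bromo would behave. They also leave open whether such a group would give similar steps on both cores.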